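The source may hold more compounds than are shown below. What is called first, only, known or untested is meant among the compounds shown, and "the series" means these compounds.

Working notes on the sulfonamide series. Compound 1 `Cc1noc(C)c1S(=O)(=O)N1CCC(N2CCC(C)CC2)CC1` carries 3,5-dimethyl-1,2-oxazol-4-yl on the sulfonyl sulfur. In an ADME assay on HCT-116 cells (Homo sapiens) for cytotoxicity, read by CellTiter-Glo, with a stated time of 72 h (on this read-out higher numbers stand for weaker inhibition and lower numbers for stronger inhibition), compound 1 gives > 10000 nM, which is a limit of the assay and not a number. Compound 2 `CC1CCN(C2CCN(S(=O)(=O)c3ccc(-c4ccccc4)cc3)CC2)CC1` gives > 5000 nM in this assay, also a limit. Compound 3 `C#CCOCCC1CCCCN1C1CCN(S(=O)(=O)c2ccccc2)CC1` gives > 5000 nM in this assay, again a limit. All three values therefore sit at limits, one at the limit of > 10000 nM in this assay, at which 1 of the 3 values shown sits, and two at the limit of > 5000 nM in this assay, at which 2 of the 3 values shown sit, so compound 1 cannot be placed above or below the others; it simply stands among compounds that show no measurable cytotoxicity on this read-out.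

Compound 4 `CC1CCN(C2CCN(S(=O)(=O)c3cc(Cl)cc(Cl)c3)CC2)CC1` has not been measured. It differs from compound 1 by 3,5-dichlorophenyl in place of 3,5-dimethyl-1,2-oxazol-4-yl on a sulfonyl sulfur. Within the data shown here, no step between measured compounds exists, and with every value so far at a limit, no shift beyond the scatter is expected in this assay. The step of a number no higher from compound 1 to compound 4 (the limit leaves the size open) is expected to stay within the scatter. Compound 4 is expected to give 10000 nM, with a range from 5000 nM to 30000 nM, most likely again reported only as a limit.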

Compound 4, half-maximal inhibitory concentration: > 5000 nM
Compound 4 was reported as a limit (the forecaster's own chance of this, stated with the estimate: 85%); the middle value is on the limit's open side.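

Among these compounds, compound 1 and compound 4 are both reported only as limits, so no step between them can be read. The compounds shown leave open whether any group on the sulfonyl sulfur gives a measurable value in this assay.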